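This account rests on a few compounds, and the source may have more. Where it says the series, first, only, none or still open, it means among the compounds named here.

Working notes on the catechol-styryl sulfone series. Compound 1 `O=S(=O)(/C=C/c1ccc(O)c(O)c1)CCC1CCCC1` and compound 2 `O=S(=O)(/C=C/c1ccc(O)c(O)c1)CCCCCCCCCCCO` have been run in a functional assay, read by fluorescence and spectrophotometry, with a stated time of 1 h; a higher number here means that more compound is needed for the effect, a lower number that less compound is needed. Compound 1 gives 6800 nM in this assay, while compound 2 gives 22600 nM, the higher of the two numbers, with the gap to compound 1 beyond the scatter. Compound 3 `CCCCCCCCCS(=O)(=O)/C=C/c1ccc(O)c(O)c1` remains to be measured in this assay. It differs from compound 2 by hydrogen in place of 2-hydroxyethyl on a saturated chain carbon, nine bonds along the chain from a sulfonyl sulfur. Among the compounds with values here, no measured pair covers this change; compound 1 gives the only other reference number. The expected step is a 2.8-fold lower number from compound 2 to compound 3 (0.45 log units; beyond the scatter), lowering the number beyond the scatter. Compound 3 is estimated at 8000 nM, in the range 3000 nM to 25000 nM.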

Compound 3, half-maximal effective concentration: 7700 nM
Compound 3: the middle estimate sits 1.0-fold (0.02 log units) above what was measured, within the range that was stated.
By their numbers in this assay, from the lowest: compounds 1 and 3 (each within the scatter of the next); then compound 2.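

In this assay, hydrogen in place of 2-hydroxyethyl on a saturated chain carbon, nine bonds along the chain from a sulfonyl sulfur, gives a 2.9-fold lower number from compound 2 to compound 3 (0.47 log units; beyond the scatter) for this position. Heptyl in place of cyclopentyl on a saturated chain carbon, two bonds along the chain from a sulfonyl sulfur, gives a 1.1-fold higher number from compound 1 to compound 3 (0.05 log units; within the scatter) and so does not separate these two groups. No measurement on hand bears on the cause of either step.

In the step from compound 2, the hydroxyl and the chain length change together, so their shares remain unresolved. On these data alone, an amine or a carboxylic acid at this position, or a longer chain without the hydroxyl, remains open.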